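Ethyl Ester Compound 4 After the Carboxy Compound 3

The compounds below may be only part of what the source reports. "The series", "measured", "known", "first", "only" and "open" are said of these compounds alone.

Three compounds share one core: compound 1 `COC(=O)/C=C/c1ccncc1-c1ccc2ccccc2c1`, compound 2 `O=C(/C=C/c1ccncc1-c1ccc2ccccc2c1)NC1CC1` and compound 3 `O=C(O)/C=C/c1ccncc1-c1ccc2ccccc2c1`. In a functional assay on MCF7 cells (Homo sapiens) for inhibition, read by sulforhodamine B assay, with a stated time of 72 h (a higher number here means a weaker inhibitor of growth, a lower number a stronger inhibitor of growth), compound 1 gives 8170 nM. Compound 2 gives 6840 nM in this assay. For compound 3 this assay reports only a limit, > 10000 nM, and not a number, so compound 3 stands at that limit and nowhere more precise, as the note the limit of > 10000 nM in this assay, at which 1 of the 3 values shown sits, records. The steps of an at least 1.2-fold higher number from compound 1 to compound 3 (0.08 log units; that floor lies within the scatter) and an at least 1.4-fold higher number from compound 2 to compound 3 (0.16 log units; that floor lies within the scatter) both end at that limit, and both floors lie within the scatter.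

Compound 4 `CCOC(=O)/C=C/c1ccncc1-c1ccc2ccccc2c1` has not yet been measured. The change from compound 3 is ethyl in place of hydrogen on an oxygen next to a carbonyl group. For the measured compounds named here, the closest precedent is the reverse of the step from compound 1 to compound 3, where the methyl compound gives a number and the carboxy compound only a limit. The step of an at least 1.1-fold lower number from compound 3 to compound 4 (0.07 log units; that floor lies within the scatter) is therefore expected in this assay, toward a lower number, returning roughly to where compound 1 stands. Compound 4 is estimated at 8500 nM, between 4000 nM and 20000 nM.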

Compound 4, concentration for 50% growth inhibition: 8320 nM
For compound 4 the middle estimate is 1.0-fold (0.01 log units) above the measured one; low and high end bracket the measured number.
By their numbers in this assay, from the lowest: compounds 2, 1 and 4 (each within the scatter of the next). At a limit, above all of these: compound 3.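

Neither the size of the alkyl group on this oxygen nor the swap to the amide registers in this assay: methyl in place of hydrogen on the ethyl chain's saturated carbon gives a 1.0-fold higher number from compound 1 to compound 4 (0.01 log units; within the scatter), and ethoxy in place of cyclopropylamino on the carbonyl carbon gives a 1.2-fold higher number from compound 2 to compound 4 (0.09 log units; within the scatter). The change from hydrogen to ethyl on the oxygen can be read only as a floor, an at least 1.2-fold lower number from compound 3 to compound 4 (0.07 log units; that floor lies within the scatter), and that floor does not separate the ethyl ester from the carboxy compound. Compound 3 stands at a limit and not a number, and the true size of this step stays unread: the limit of > 10000 nM in this assay, at which 1 of the 4 values shown sits.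

The compounds shown leave open whether a longer chain such as butyl, or a benzyl group, on this oxygen would move the number beyond the scatter. They also leave open what a simple unsubstituted amide on the carbonyl carbon would do.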